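The compounds below may be only part of what the source reports. "The series", "measured", "known", "first", "only" and "open" are said of these compounds alone.

Compound 1 `COc1ccc(/C(F)=C/c2cc(OC)c(OC)c(OC)c2)cc1N` and compound 2 `COc1ccc(/C=C(/F)c2cc(OC)c(OC)c(OC)c2)cc1N` are built from the same atoms joined differently; the difference between the two cores is not broken down here. In a functional assay on cells (Endothelial cell, Bos taurus) for antiproliferative activity (on this read-out higher numbers stand for weaker inhibition and lower numbers for stronger inhibition), compound 1 gives 111000 nM, while compound 2 gives 2000 nM. Compound 3 `COc1ccc(/C(F)=C/c2cc(OC)c(OC)c(OC)c2)cc1[N+](=O)[O-]` differs from compound 1 by nitro in place of amino on an aromatic carbon. For compound 3 this assay reports only a limit, > 3000000 nM. The step of an at least 27-fold higher number from compound 1 to compound 3 (1.43 log units; beyond the scatter) therefore rests on (the limit of > 3000000 nM in this assay, at which 1 of the 3 values shown sits), so its true size is not fixed. Compound 4 `COc1ccc(/C=C(/F)c2cc(OC)c(OC)c(OC)c2)cc1[N+](=O)[O-]` is still to be measured and differs from compound 2 by the same change, (nitro in place of amino on an aromatic carbon), at a place described in identical words. Given the single earlier step from compound 1 to compound 3, compound 4 is expected to sit far weaker than compound 2, by roughly a 75-fold higher number from compound 2 to compound 4 (1.88 log units; beyond the scatter), and its estimated value is 150000 nM, between 20000 nM and 3000000 nM.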

Compound 4, half-maximal inhibitory concentration: 38400 nM
Estimate against measurement, compound 4: 3.9-fold (0.59 log units) above; the range from low to high includes it.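

In this assay nitro in place of amino again weakens inhibition on the second core, and the step is large (a 19-fold higher number from compound 2 to compound 4 (1.28 log units; beyond the scatter)). The direction of the change therefore carries over between the core of compound 1 and the core of compound 2, though this rests on only these two pairs. Its size cannot be said to carry over, since one of the two steps rests on a limit: the same change on two cores in this assay, an at least 27-fold higher number (1.43 log units; beyond the scatter) from compound 1 to compound 3 and a 19-fold higher number (1.28 log units; beyond the scatter) from compound 2 to compound 4; the limit leaves it open whether they differ.

The compounds shown leave open how other groups at this place, such as a hydroxyl group or an acetamide, would compare with amino and nitro on either core. They also leave open whether the change would behave alike on a core lacking the fluorine.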